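From 3-fluorophenyl to 4-fluorophenyl on the shared core

The compounds below may be only part of what the source reports. "The series", "measured", "known", "first", "only" and "open" are said of these compounds alone.

In an ADME assay on THP-1 cells (Homo sapiens) for cytotoxicity, read by flow cytometry and propidium iodide staining, with a stated time of 72 h (a higher number here means a weaker inhibitor, a lower number a stronger inhibitor), compound 3 (`COc1c(-c2cccc(F)c2)oc2ccc(N)cc2c1=O`) gives 34000 nM and compound 2 (`COc1ccc(-c2oc3ccc(N)cc3c(=O)c2OC)cc1`) gives 21000 nM, two values within the scatter of each other. Compound 1 (`COc1c(-c2ccc(F)cc2)oc2ccc(NC(C)=O)cc2c1=O`) reads > 125000 nM, which is a limit of the assay and not a number.

Compound 4 (`COc1c(-c2ccc(F)cc2)oc2ccc(N)cc2c1=O`) has not yet been measured. It carries 4-fluorophenyl in place of 3-fluorophenyl on an aromatic carbon. For the measured compounds named here, the two compounds have the same atoms, joined differently, and no measured pair isolates this change. Compound 3 at 34000 nM therefore anchors the expectation. In this assay the estimated step is a 1.1-fold lower number from compound 3 to compound 4 (0.05 log units; within the scatter), which is expected to stay within the scatter, with no direction favoured. The estimate for compound 4 is 30000 nM, with an expected range of 14000 nM to 65000 nM.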

Compound 4, half-maximal inhibitory concentration: 36000 nM
Compound 4: middle estimate off by 1.2-fold (0.08 log units), on the low side; the range from low to high includes it.
By their numbers in this assay, from the lowest: compounds 2, 3 and 4 (each within the scatter of the next). At a limit, above all of these: compound 1.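

In this assay 4-fluorophenyl in place of 3-fluorophenyl, next to the ring oxygen, gives a 1.1-fold higher number from compound 3 to compound 4 (0.02 log units; within the scatter) and fluoro in place of methoxy gives a 1.7-fold higher number from compound 2 to compound 4 (0.23 log units; within the scatter) and so neither change separates these compounds. Hydrogen in place of acetyl on the nitrogen gives an at least 3.4-fold lower number from compound 1 to compound 4 (0.54 log units; beyond the scatter) as the only one of these steps beyond the scatter. Compound 1 stands at a limit of the assay and not at a number, so this step has only a bound: the limit of > 125000 nM in this assay, at which 1 of the 4 values shown sits.

Open, going by these compounds, is whether a carboxylic acid or an amine in place of the fluorine, or a longer chain in place of acetyl on the nitrogen, would give a step beyond the scatter.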